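The source may hold more compounds than are shown below. What is called first, only, known or untested is meant among the compounds shown, and "the series" means these compounds.

In a functional assay on cells (Mast cell, Rattus norvegicus, strain Wistar) for activation, read by fluorescence, with a stated time of 15 min (a lower number here means that less compound is needed, a higher number that more compound is needed for the effect), three lysophospholipid-type compounds have been tested so far. Compound 1, `CCCCCCCCCCCCCCCCCC(=O)OC[C@@H](O)COP(=O)(O)OC[C@H](N)C(=O)OC`, gives > 10000 nM, which is a limit of the assay and not a number. Compound 2, `CCCCCCCCCCCCCCCCCC(=O)OC[C@@H](O)COP(=O)(O)OC[C@H](NC)C(=O)O`, gives > 10000 nM, again a limit. Compound 3, `CCCCCCCCCCCCCCCCCC(=O)OC[C@@H](O)COP(=O)(O)O[C@@H]1CN[C@@H](C(=O)O)C1`, gives > 10000 nM, also a limit. Compound 3 therefore has no number of its own and stands with the other two at the limit of > 10000 nM in this assay, at which 3 of the 3 values shown sit.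

Compound 4, `CCCCCCCCCCCCCCCCCC(=O)OC[C@@H](O)COP(=O)(O)O[C@H]1CN[C@@H](C(=O)O)C1`, has yet to be measured. The change is the two compounds have the same atoms and bonds; at least one stereo element is drawn with a configuration in one of them and without one in the other: 1 of 4 stereo elements differ; a stereocentre at a saturated ring carbon is drawn S in compound 3 and R in compound 4. Thus, the two compounds have the same atoms and bonds, and a stereocentre at a saturated ring carbon is drawn S in compound 3 and R in compound 4.

Two measured steps lead to compound 3, a step that the two limits leave unreadable from compound 1 to compound 3 and a step that the two limits leave unreadable from compound 2 to compound 3. Neither has a readable size, and neither changes only a stereocentre, so they give no measure for this inversion. For the measured compounds named here, the only guide is the shared limit, and compound 4 is expected to stay close to it, most likely again without a number. The expected step is a step that the limit leaves unreadable from compound 3 to compound 4, with no direction that the data can support. The estimate for compound 4 is 12000 nM, with an expected range from 2000 nM to 30000 nM.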

Compound 4, half-maximal effective concentration: > 10000 nM
Compound 4: no number, only a limit (the forecaster's own chance of this, stated with the estimate: 75%); the middle value does not contradict the limit.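

In this assay compound 4 gives > 10000 nM, which is a limit of the assay and not a number. No step between compounds 1, 2, 3 and 4 can be read, as all share one limit: the limit of > 10000 nM in this assay, at which 4 of the 4 values shown sit.

The compounds shown leave open whether the stereocentre drawn S in compound 3 and R in compound 4 matters in this assay at all.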